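A few compounds are considered here, and "the series" means these few. Any claim that something is new, unique, unknown or untested is made for them only; others in the source may bear on it.

Compound 3 `N#Cc1ccc(C(=O)N2CCC3(CC2)CN(C(=O)Nc2ccc(C(F)(F)F)cc2)CCO3)cc1` is the starting point of this step. In an ADME assay for solubility, in simulated intestinal fluid (a higher number here means a more soluble compound, a lower number a less soluble compound), compound 3 gives 82 ug/mL. Two related compounds have been measured in the same way: compound 1 `O=C(Nc1ccc(C(F)(F)F)cc1)N1CCOC2(CCN(C(=O)c3ccco3)CC2)C1` gives 75 ug/mL, and compound 2 `O=C(Nc1ccc(OC(F)(F)F)cc1)N1CCOC2(CCN(C(=O)c3ccccc3F)CC2)C1` gives 62 ug/mL. All three numbers lie within the usual scatter of one another, so compound 3 stands level with compounds 1 and 2 rather than apart from them.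

The change from compound 3 to compound 4 `O=C(Nc1ccc(C(F)(F)F)cc1)N1CCOC2(CCN(C(=O)c3c(F)cccc3F)CC2)C1` is 2,6-difluorophenyl in place of 4-cyanophenyl on a carbonyl carbon. Among the measured compounds shown here, only one measured step touches the same carbonyl carbon: a 1.1-fold higher number from compound 1 to compound 3 (0.04 log units; within the scatter). For the measured compounds named here, compound 2 differs from compound 3 in two places at once, so no single step can be drawn from it; its value simply sits among the others. One exchange of the aryl group on this carbonyl carbon left the number within the scatter, and the move to 2,6-difluorophenyl is expected to behave alike. The expected step is a 1.3-fold lower number from compound 3 to compound 4 (0.10 log units; within the scatter), and compound 4 is estimated at 65 ug/mL, between 35 ug/mL and 120 ug/mL.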

Compound 4, solubility: 38 ug/mL
For compound 4 the middle estimate is 1.7-fold (0.23 log units) above the measured one; measured number inside the range.
By their numbers in this assay, from the lowest: compounds 4, 2, 1 and 3 (each within the scatter of the next, the first and the last beyond it).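

In this assay, among the compounds shown here, this carbonyl carbon shows a 2.2-fold lower number from compound 3 to compound 4 (0.33 log units; beyond the scatter) as a modest step, the first exchange here at this place to pass beyond the scatter, so the group on it is not always without consequence. Set against furan-2-yl, the same 2,6-difluorophenyl group gives a 2.0-fold lower number from compound 1 to compound 4 (0.30 log units; within the scatter) and stays within the scatter, so the clear separation holds only against 4-cyanophenyl. Nothing available bears on what lies behind the step, which stands here as an observation only.

For the compounds shown here, only three groups on this carbonyl carbon can be compared directly, so no rule for the position can be drawn from them. Going by these compounds, what an amine or a carboxylic acid carried on the aryl group would do to this number remains open.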